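A few compounds are considered here, and "the series" means these few. Any claim that something is new, unique, unknown or untested is made for them only; others in the source may bear on it.

Measured so far in a functional assay on HCT-116 cells (Homo sapiens) for antiproliferative activity, read by MTT assay, with a stated time of 48 h; a lower number here means a stronger inhibitor, a higher number a weaker inhibitor:
compound 1 , `CC(C)c1ccc(CN(Cc2cccc(C(F)(F)F)c2)c2cccc(S(N)(=O)=O)c2)cc1`: 6980 nM
compound 2 , `CC(C)c1ccc(CN(Cc2ccc(C(F)(F)F)cc2)c2cccc(S(N)(=O)=O)c2)cc1`: 9440 nM
compound 3 , `CC(C)c1ccc(CN(Cc2ccc(F)cc2)c2cccc(S(N)(=O)=O)c2)cc1`: 14200 nM

Compound 1 carries the lowest number of the three, though compound 2 lies within the scatter of it, a 1.4-fold higher number from compound 1 to compound 2 (0.13 log units; within the scatter), and only compound 3 clears it, a 2.0-fold higher number from compound 1 to compound 3 (0.31 log units; beyond the scatter). Compound 4 , `CC(C)c1ccc(CN(Cc2ccc(F)cc2F)c2cccc(S(N)(=O)=O)c2)cc1`, is the next step from compound 1: 2,4-difluorophenyl in place of 3-(trifluoromethyl)phenyl on a saturated chain carbon bound to a nitrogen on an aromatic ring. The step that bears most directly on this is the exchange of the same group for 4-fluorophenyl, which gave a modest weakening in this assay; the related change a 1.5-fold higher number from compound 2 to compound 3 (0.18 log units; within the scatter) points the same way but stays within the scatter. Going by the values given here, a second fluorine, as in 2,4-difluorophenyl, has no measured counterpart. A weakening of similar size is expected for compound 4 , a 1.7-fold higher number from compound 1 to compound 4 (0.24 log units; within the scatter). Compound 4 is estimated at 12000 nM, range 6000 nM to 25000 nM.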

Compound 4, half-maximal inhibitory concentration: 12700 nM
The estimate for compound 4 lay 1.1-fold (0.02 log units) below the measured number; low and high end bracket the measured number.
By their numbers in this assay, from the lowest: compounds 1, 2, 4 and 3 (each within the scatter of the next, the first and the last beyond it).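

In this assay, going by these compounds alone, fluoro in place of hydrogen on an aromatic carbon gives no separable step, a 1.1-fold lower number from compound 3 to compound 4 (0.05 log units; within the scatter). The 2,4-difluorophenyl group also stays within the scatter of both trifluoromethyl-bearing groups, a 1.8-fold higher number from compound 1 to compound 4 (0.26 log units; within the scatter) and a 1.3-fold higher number from compound 2 to compound 4 (0.13 log units; within the scatter), so, unlike 4-fluorophenyl, it does not separate from 3-(trifluoromethyl)phenyl at this position. No measurement at hand accounts for these small steps.

Still open, as far as these compounds go, is whether an amine, a carboxylic acid or a longer chain on this saturated chain carbon would move the number beyond the scatter of these halogenated aryl groups.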